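The compounds below may be only part of what the source reports. "The series", "measured", "known", "first", "only" and "open" are said of these compounds alone.

Working notes on the series. Compound 2 `COc1cc(C2CCN(C(=O)C3CCN3)CC2)ccc1Nc1ncc2ccc(-c3ccccc3OC)n2n1` has the highest number of the two measured: in an in vivo ADME assay on the whole organism (strain Sprague-Dawley) for pharmacokinetics, with Rattus norvegicus as the target, at a dose of 5 mg/kg by the oral route (a lower number here means that a smaller share of the oral dose reaches the circulation, a higher number that a larger share of the oral dose reaches the circulation), compound 2 gives 15%, while compound 1 `COc1cc(C2CCN(C)CC2)ccc1Nc1ncc2ccc(-c3ccccc3OC)n2n1` gives 3%. Within the data shown here, the one measured step at this position of the shared core, a number 12 percentage points higher from compound 1 to compound 2 (beyond the scatter), is the only guide available. Among the measured compounds shown here, compound 3 `COc1cc(C2CCN(CC(N)=O)CC2)ccc1Nc1ncc2ccc(-c3ccccc3OC)n2n1` differs from compound 2 by carbamoylmethyl in place of (azetidin-2-yl)carbonyl on an amine nitrogen in a ring; no measured pair shows this exchange, so the step of a number 12 percentage points higher from compound 1 to compound 2 (beyond the scatter) bears on it only as a change at the same amine nitrogen in a ring, with a different group entering. The expectation is therefore a modest step downward in this assay, smaller than the step already in hand at this position and not clearly beyond the scatter, as a number 7 percentage points lower from compound 2 to compound 3 (within the scatter). For compound 3 the estimate in this assay is 8%, within 2% to 20%.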

Compound 3, oral bioavailability: 43%
Beside the measured number, compound 3's estimate is 35 percentage points below it; measured number above the stated range.
By their numbers in this assay, from the lowest: compound 1; then compound 2; then compound 3.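

In this assay the group on the amine nitrogen in a ring can move the number much further than the step from methyl to (azetidin-2-yl)carbonyl showed: carbamoylmethyl in place of (azetidin-2-yl)carbonyl brings a number 28 percentage points higher from compound 2 to compound 3 (beyond the scatter) and carbamoyl in place of hydrogen on the saturated chain carbon brings a number 40 percentage points higher from compound 1 to compound 3 (beyond the scatter) in a single exchange. The highest of the three numbers belongs to compound 3, whose group has no ring and fewer heavy atoms than the (azetidin-2-yl)carbonyl, so neither that ring nor a carbonyl bound directly to the nitrogen is required for a rise. Nothing available accounts for the size of this change.

From the compounds shown here alone, whether the carbamoyl end itself matters stays open. A carboxylic acid, a nitrile or a longer chain ending in carbamoyl on the same nitrogen would test this.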